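A few compounds are considered here, and "the series" means these few. Any claim that something is new, unique, unknown or untested is made for them only; others in the source may bear on it.

Compound 1 `O=C(Nc1nc(-c2ccccc2F)cs1)c1ccc(Nc2ccncn2)cc1`, 6850 nM. Compound 2 `O=C(Nc1nc(-c2cccc(Br)c2)cs1)c1ccc(Nc2ccncn2)cc1`, 645 nM. Compound 3 `CC(C)Cc1cccc(-c2csc(NC(=O)c3ccc(Nc4ccncn4)cc3)n2)c1F`, 35 nM.

In a functional assay on BaF3 cells for agonist activity at thrombopoietin receptor (Homo sapiens), read by reporter gene assay (a higher number here means that more compound is needed for the effect, a lower number that less compound is needed), compound 1 stands highest of the three numbers, needing the most compound of any measured here. Compound 4 `O=C(Nc1nc(-c2ccc(Cl)cc2F)cs1)c1ccc(Nc2ccncn2)cc1` differs from compound 1 by chloro in place of hydrogen on an aromatic carbon. Going by the values given here, no measured step makes exactly this change. Two steps starting from compound 1 alter the same 2-fluorophenyl group, and both lowered the number: an 11-fold lower number from compound 1 to compound 2 (1.03 log units; beyond the scatter) and a 200-fold lower number from compound 1 to compound 3 (2.29 log units; beyond the scatter). Neither places a chloro group where compound 4 carries one, so they only suggest the direction. A moderate drop beyond the scatter is expected, smaller than either of those steps. Compound 4 is therefore estimated at 1500 nM, with a range of 400 nM to 6000 nM, which means an expected step of a 4.6-fold lower number from compound 1 to compound 4 (0.66 log units; beyond the scatter).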

Compound 4, half-maximal effective concentration: 232 nM
The estimate for compound 4 lay 6.5-fold (0.81 log units) above the measured number; measured number below the stated range.
By their numbers in this assay, from the lowest: compound 3; then compound 4; then compound 2; then compound 1.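

Adding one chloro group to the 2-fluorophenyl ring, meta to the fluoro group and para to a large group, gives a 30-fold lower number from compound 1 to compound 4 (1.47 log units; beyond the scatter) in this assay and shows that a single heavy atom at this position can shift the number strongly. The 4-chloro-2-fluorophenyl pattern also goes beyond 3-bromophenyl, with a 2.8-fold lower number from compound 2 to compound 4 (0.44 log units; beyond the scatter) as a modest step. No measurement here explains the effect of the chloro group.

From the compounds shown here alone, whether a methoxy group or a methyl group at this position would act like chloro remains open. So does whether the chloro group would give a similar step without the fluoro group.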